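A few compounds are considered here, and "the series" means these few. Any claim that something is new, unique, unknown or untested is made for them only; others in the source may bear on it.

Measured so far:

compound 1, `N=C(N)c1ccc(-c2cc(-c3cccc(C(=N)N)c3[N+](=O)[O-])no2)cc1`: 5100 nM
compound 2, `N=C(N)c1ccc(-c2cc(-c3cccc(C(=N)N)c3Cl)no2)cc1`: 5700 nM
compound 3, `N=C(N)c1cccc(-c2cc(-c3cccc(C(=N)N)c3[N+](=O)[O-])on2)c1`: 9800 nM

All three were tested in an ADME assay on L6 cells (Rattus norvegicus) for cytotoxicity; on this read-out lower numbers stand for stronger inhibition and higher numbers for weaker inhibition. Compound 1 and compound 2 share one core and differ in a single spot: chloro in place of nitro on an aromatic carbon. That change gave a 1.1-fold higher number from compound 1 to compound 2 (0.05 log units; within the scatter), so on this read-out the two compounds cannot be told apart. Compound 3 is built from the same atoms as compound 1, joined differently, and the difference between the two cores is not broken down here. Its value and the values of compound 1 and compound 2 all lie within the usual scatter of one another, so no order among the three can be claimed.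

Compound 4, `N=C(N)c1cccc(-c2cc(-c3cccc(C(=N)N)c3Cl)on2)c1`, has not yet been measured. It stands to compound 3 as compound 2 stands to compound 1: chloro in place of nitro on an aromatic carbon. The surroundings of the change are described in the same words in both pairs, so it is the same change carried onto a different core.

For the measured compounds named here, compound 4 is expected to show a 1.1-fold higher number from compound 3 to compound 4 (0.03 log units; within the scatter) in this assay, set beside the one earlier example, a 1.1-fold higher number from compound 1 to compound 2 (0.05 log units; within the scatter). This expectation rests on a 1.1-fold higher number from compound 1 to compound 2 (0.05 log units; within the scatter) alone, a single precedent on a core that is not the core of compound 3. The estimate for compound 4 in this assay is 10500 nM, with a range from 5000 nM to 22000 nM that allows for the scatter and for the thinness of the precedent.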

Compound 4, half-maximal inhibitory concentration: 109000 nM
For compound 4 the middle estimate is 10-fold (1.02 log units) below the measured one, outside the stated range (above it).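

In this assay putting chloro in place of nitro gave an 11-fold higher number from compound 3 to compound 4 (1.05 log units; beyond the scatter) and so did not behave as it had on the other core: the same change on two cores in this assay, a 1.1-fold higher number (0.05 log units; within the scatter) from compound 1 to compound 2 and an 11-fold higher number (1.05 log units; beyond the scatter) from compound 3 to compound 4, 10-fold (1.00 log units) apart, beyond the scatter of two such steps.

On the core of compound 1 the swap left the two compounds indistinguishable, while on the core of compound 3 it clearly weakened inhibition, so in this series a step seen on one core is not a safe guide to the same step on the other. For the compounds shown here, what this does not show is why the two cores part ways, since there is only one pair on each core and nothing here separates which feature of the cores matters or says how the change acts.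

The compounds shown leave open how other groups at this spot, such as an amine or a carboxylic acid, would behave on each of the two cores. They also leave open whether the large step is specific to the swap of nitro for chloro or would appear with other replacements on the core of compound 3.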